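A few compounds are considered here, and "the series" means these few. Any claim that something is new, unique, unknown or untested is made for them only; others in the source may bear on it.

In a functional assay on KBVIN cells (Homo sapiens) for cytotoxicity, read by sulforhodamine B assay, with a stated time of 3 days (on this read-out lower numbers stand for an effect already at smaller amounts and higher numbers for an effect only at larger amounts of compound), compound 1 `CCOCc1c(C)coc1-c1ccc2c(c1OC)CCCC2(C)C` gives 16.5 uM and compound 2 `Cc1coc(-c2ccc3c(c2O)CCCC3)c1C(=O)O` gives 29.4 uM. Going by the values given here, these two values lie within the usual scatter of each other, so no order can be read between them, and compound 1 stands level with compound 2 on the numbers so far. The two structures also differ in more than one place, so this comparison cannot be tied to any single group.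

Compound 3 `COC(=O)c1c(C)coc1-c1ccc2c(c1OC)CCCC2(C)C` keeps the core of compound 1 and changes one group: methoxycarbonyl in place of ethoxymethyl on an aromatic carbon. Here, methoxycarbonyl replaces ethoxymethyl on an aromatic carbon of a five-membered aromatic ring with 1 oxygen. Among the compounds with values here, no measured pair shows a change at this place, so the data offer no direct guide to the size of the step. The expectation in this assay is therefore cautious: no step beyond the scatter, in either direction. For compound 3 the expected value is 20 uM, with an estimated range from 8 uM to 45 uM. Put as a step, the estimate is an expected 1.2-fold higher number from compound 1 to compound 3 (0.08 log units; within the scatter).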

Compound 3, concentration for half-maximal effect: 52.1 uM
Estimate against measurement, compound 3: 2.6-fold (0.42 log units) below, and the stated range ends below it.
By their numbers in this assay, from the lowest: compounds 1, 2 and 3 (each within the scatter of the next, the first and the last beyond it).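

Going by these compounds alone, this is the first step in this assay that can be tied to a single place: on an aromatic carbon of the five-membered aromatic ring with 1 oxygen, methoxycarbonyl in place of ethoxymethyl gives a 3.2-fold higher number from compound 1 to compound 3 (0.50 log units; beyond the scatter). The position is therefore not indifferent to what it carries, since the two groups have the same count of 4 heavy atoms, neither has a ring and neither has a net charge, yet their numbers lie apart, with the lower number belonging to the ethoxymethyl of compound 1. Nothing measured here accounts for this difference.

Within the data shown here, with only two groups compared at this place on this core, it remains open how a hydroxymethyl, an aminomethyl, an amide or a longer ether chain such as propoxymethyl would read in this assay. Also open, from the compounds shown here alone, is whether the same swap would give a similar step on a different core, a question that compound 2 cannot settle, as it differs from both compound 1 and compound 3 in more than one place.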